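Compound 3: 3,4-dichlorophenyl in place of carbamoyl

The source may report more compounds than this note shows. Statements on the series, on what has been measured and on what is new or still open speak of the compounds shown alone.

- compound 1 `C=C[C@@](C)(/C=C/c1ccc(O)c(/C=C/C(=O)OCC)c1)CCC=C(C)C`: > 36600 nM (a limit)
- compound 2 `C=C[C@@](C)(/C=C/c1ccc(O)c(/C=C/C(N)=O)c1)CCC=C(C)C`: > 36600 nM (a limit)

In a functional assay on SEM cells (Homo sapiens) for cytotoxicity, with a stated time of 72 h (on this read-out lower numbers stand for an effect already at smaller amounts and higher numbers for an effect only at larger amounts of compound), compound 2 gives > 36600 nM, a limit of the assay and not a number. Among the compounds with values here, the only measured step, a step that the two limits leave unreadable from compound 1 to compound 2, offers no size to carry forward, and the record so far is the limit of > 36600 nM in this assay, at which 2 of the 2 values shown sit. Compound 3 `C=C[C@@](C)(/C=C/c1ccc(O)c(/C=C/c2ccc(Cl)c(Cl)c2)c1)CCC=C(C)C` is the next structure, with this change: 3,4-dichlorophenyl in place of carbamoyl on a double-bonded chain carbon bound to a double-bonded chain carbon. With so large a change, a move toward lower numbers is expected, though its size is poorly fixed and it may not clear the limit. The estimated step is expected to be an at least 2.4-fold lower number from compound 2 to compound 3 (0.38 log units; beyond the scatter). The expected value for compound 3 is 15000 nM, with an estimated range from 5000 nM to 40000 nM.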

Compound 3, half-maximal effective concentration: > 7500 nM
Compound 3 gave a limit, no number; the forecaster's own chance of this, stated with the estimate: 40%; the middle value lies beyond the limit too.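

In this assay, within the data shown here, compound 1, compound 2 and compound 3 all give limits, not numbers, so no step among them can be read. As far as these compounds go, how ethoxycarbonyl, carbamoyl and 3,4-dichlorophenyl rank against one another stays open.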